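Shortening the ether chain on a glutamate-like core

This account rests on a few compounds, and the source may have more. Where it says the series, first, only, none or still open, it means among the compounds named here.

Compound 1 `CCC(C)O[C@@H]1C[C@@H]2[C@H]([C@]1(N)C(=O)O)[C@@]2(F)C(=O)O`, 6.68 nM
Compound 2 `N[C@]1(C(=O)O)[C@H]2[C@@H](C[C@H]1OCCCc1ccccc1)[C@]2(F)C(=O)O`, 9.83 nM

Both compounds share the same core and differ only in the group carried on the ether oxygen. In an assay on CHO cells for binding affinity to metabotropic glutamate receptor 2 (Rattus norvegicus) (on this read-out lower numbers stand for stronger inhibition and higher numbers for weaker inhibition), compound 1 gives 6.68 nM, and in this assay compound 2 gives 9.83 nM. Compound 2 has the higher of these two numbers, but the gap to compound 1 lies within the scatter, so the two cannot be ranked against each other.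

Compound 3 `N[C@]1(C(=O)O)[C@H]2[C@@H](C[C@H]1OCc1cccc(F)c1F)[C@]2(F)C(=O)O` keeps the core of compound 2 and changes only the ether substituent: 2,3-difluorophenyl in place of phenethyl on a saturated chain carbon bound to an oxygen on a saturated carbon. The aromatic ring is thereby drawn closer to the oxygen, and two fluorine atoms are placed on it. Going by the values given here, no measured pair shows this kind of change, so there is no direct guide for the direction of the step. The expectation is that compound 3 remains close to the range of the measured pair, with a slight move towards a lower number, so the step of a 2.0-fold lower number from compound 2 to compound 3 (0.29 log units; within the scatter) is estimated to stay within or just beyond the scatter. For compound 3 the expected value in this assay is 5 nM, with a likely range from 1.5 nM to 16 nM.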

Compound 3, inhibition constant: 4.25 nM
The estimate for compound 3 lay 1.2-fold (0.07 log units) above the measured number; measured number inside the range.
By their numbers in this assay, from the lowest: compounds 3, 1 and 2 (each within the scatter of the next, the first and the last beyond it).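

Placing 2,3-difluorophenyl in place of phenethyl on a saturated chain carbon bound to an oxygen on a saturated carbon gives a 2.3-fold lower number from compound 2 to compound 3 (0.36 log units; beyond the scatter) in this assay, the first difference in this set that clearly exceeds normal measurement noise. The effect is modest, so this position accepts a substantial change of group while the number stays in the same low range. Nothing available here explains why the number moves.

This single step changes both the chain and the fluorine content of the ring, so the shown compounds cannot separate the contribution of each. A plain phenyl group in the same place would test the role of the fluorine atoms, while an amine on the chain would show how this position responds to a very different group.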